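A few compounds are considered here, and "the series" means these few. Any claim that something is new, unique, unknown or untested is made for them only; others in the source may bear on it.

Measured so far:
Compound 1, `Nc1ncnc2c1c(Oc1cc(C(F)(F)F)ccn1)nn2C1CC1`: in an ADME assay on microsomes from liver (Homo sapiens) for metabolic stability, read by LC-MS, using NADPH, with a stated time of 10 min, tested at 10 uM (a higher number here means that the compound lasts longer, a lower number that the compound disappears faster), compound 1 reaches > 2.41 h, which is a limit of the assay rather than a number.
Compound 2, `Nc1ncnc2c1c(Oc1cc(C(F)(F)F)ccn1)nn2[C@H]1C[C@H](F)C1`: in this assay compound 2 gives 2.03 h.
Compound 3, `Nc1ncnc2c1c(Oc1cc(Cl)ccn1)nn2[C@H]1C[C@H](F)C1`: in this assay compound 3 gives 0.833 h.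

The change from compound 2 to compound 1 is cyclopropyl in place of 3-fluorocyclobutyl on an aromatic nitrogen; it made an at least 1.1-fold higher number from compound 2 to compound 1 (0.07 log units; that floor lies within the scatter). Compound 4, `Nc1ncnc2c1c(Oc1cc(Cl)ccn1)nn2C1CC1`, is not yet measured and differs from compound 3 by cyclopropyl in place of 3-fluorocyclobutyl on an aromatic nitrogen. The surroundings of that place differ only in wording, a ring atom that "bears a group of 8 heavy atoms" against one that "bears a large group", so this is the same kind of change. The two cores differ by chloro in place of trifluoromethyl on an aromatic carbon, which made a 2.4-fold lower number from compound 2 to compound 3 (0.39 log units; beyond the scatter). For compound 4 the expected step is a 1.2-fold higher number from compound 3 to compound 4 (0.08 log units; within the scatter), resting on an at least 1.1-fold higher number from compound 2 to compound 1 (0.07 log units; that floor lies within the scatter). The estimate for compound 4 is 1 h, expected to lie between 0.5 h and 2 h.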

Compound 4, half-life: 1.05 h
For compound 4 the middle estimate is 1.1-fold (0.02 log units) below the measured one, within the range that was stated.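

On the core of compound 3, cyclopropyl in place of 3-fluorocyclobutyl gives a 1.3-fold higher number from compound 3 to compound 4 (0.10 log units; within the scatter) in this assay, and the earlier pair points the same way, so this swap shows no clear change on either core: the same change on two cores in this assay, an at least 1.1-fold higher number (0.07 log units; that floor lies within the scatter) from compound 2 to compound 1 and a 1.3-fold higher number (0.10 log units; within the scatter) from compound 3 to compound 4; the limit leaves it open whether they differ Chloro in place of trifluoromethyl gives an at least 2.2-fold lower number from compound 1 to compound 4 (0.36 log units; beyond the scatter), so the drop seen on one core also appears on the other: the same change on two cores in this assay, a 2.4-fold lower number (0.39 log units; beyond the scatter) from compound 2 to compound 3 and an at least 2.2-fold lower number (0.36 log units; beyond the scatter) from compound 1 to compound 4; the limit leaves it open whether they differ Compound 1 gives > 2.41 h, which is a limit and not a number, so equal step sizes on the two cores are not shown: the limit of > 2.41 h in this assay, at which 1 of the 4 values shown sits.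

Still open, as far as these compounds go, is whether a nitrile on that aromatic carbon, or an isopropyl group on the aromatic nitrogen, would follow the same steps.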